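Trading thiophen-2-yl for 2,5-dimethylthiophen-3-yl

The source may hold more compounds than are shown below. What is called first, only, known or untested is meant among the compounds shown, and "the series" means these compounds.

In a functional assay on cells (Leukemia cell, Homo sapiens) for inhibition (a higher number here means a weaker inhibitor of growth, a lower number a stronger inhibitor of growth), compound 3 (`N=C(N)N/N=C/c1c(-c2cccs2)nc2sccn12`) stands at 6760 nM in the same range as compound 2 (`N=C(N)N/N=C/c1c(-c2ccsc2)nc2sccn12`) with 6920 nM and clearly lower than compound 1 (`Cc1cc(-c2nc3sc(C)cn3c2/C=N/NC(=N)N)c(C)s1`) with 47900 nM as its reading. Compound 4 (`Cc1cc(-c2nc3sccn3c2/C=N/NC(=N)N)c(C)s1`) carries 2,5-dimethylthiophen-3-yl in place of thiophen-2-yl (2,5-dimethylthiophen-3-yl in place of thiophen-2-yl on an aromatic carbon). Within the data shown here, the one measured step (a 1.0-fold lower number from compound 2 to compound 3 (0.01 log units; within the scatter)) exchanges thiophen-3-yl for thiophen-2-yl and stays within the scatter, so it says nothing about the dimethyl group. Compound 1 (47900 nM) carries the same 2,5-dimethylthiophen-3-yl on its own core and so points to a higher number in this assay rather than a lower one. A moderate rise is expected (a 2.7-fold higher number from compound 3 to compound 4 (0.43 log units; beyond the scatter)). Compound 4 is estimated at 18000 nM (expected range 7000 nM to 45000 nM).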

Compound 4, concentration for 50% growth inhibition: 15500 nM
Compound 4: middle estimate off by 1.2-fold (0.06 log units), on the high side, within the range that was stated.
By their numbers in this assay, from the lowest: compounds 3 and 2 (each within the scatter of the next); then compound 4; then compound 1.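

In this assay the steps of a 2.3-fold higher number from compound 3 to compound 4 (0.36 log units; beyond the scatter) and a 2.2-fold higher number from compound 2 to compound 4 (0.35 log units; beyond the scatter) show that 2,5-dimethylthiophen-3-yl at this position gives a modest rise over either unsubstituted thiophene on the shared core. With that group held constant, the step of a 3.1-fold lower number from compound 1 to compound 4 (0.49 log units; beyond the scatter) shows that the methyl on the core of compound 1 adds a rise of its own. No evidence at hand explains either rise. As far as these compounds go, it remains open which of the two thiophene methyl groups matters, and how an amine or a carboxylic acid on this ring would read.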